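The compounds below may be only part of what the source reports. "The series", "measured", "known", "first", "only" and "open" are said of these compounds alone.

Measured compounds:
compound 1 `COc1cc(-c2cc(COCc3cn(Cc4cc(-c5ccccc5)cnc4Cl)nn3)on2)cc(OC)c1OC` with 43100 nM in a functional assay on HeLa cells (Homo sapiens) for cytotoxicity, read by MTT assay, with a stated time of 48 h; a higher number here means a weaker inhibitor, a lower number a stronger inhibitor;
compound 2 `COc1cc(-c2cc(COCc3cn(Cc4cc(-c5ccc(C)cc5)cnc4Cl)nn3)on2)cc(OC)c1OC` with 35300 nM in this assay;
compound 3 `COc1cc(C2=NOC(COCc3cn(Cc4cc(-c5ccccc5)cnc4Cl)nn3)C2)cc(OC)c1OC` with 7300 nM in this assay.

Compound 3 gives the lowest number of the three, and its distances to compound 2 and to compound 1 lie beyond the scatter. How the core of compound 3 differs from the core of compound 1 is not broken down here. Compound 2 differs from compound 1 by methyl in place of hydrogen on an aromatic carbon, and that change made a 1.2-fold lower number from compound 1 to compound 2 (0.09 log units; within the scatter).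

Compound 4 `COc1cc(C2=NOC(COCc3cn(Cc4cc(-c5ccc(C)cc5)cnc4Cl)nn3)C2)cc(OC)c1OC` is not yet measured. It differs from compound 3 by methyl in place of hydrogen on an aromatic carbon, the same change, at the same place, made on the core of compound 3. Because the earlier step of a 1.2-fold lower number from compound 1 to compound 2 (0.09 log units; within the scatter) stayed within the scatter, compound 4 is expected to stay close to compound 3, with an expected step of a 1.1-fold lower number from compound 3 to compound 4 (0.05 log units; within the scatter). The estimate for compound 4 in this assay is 6500 nM, between 3000 nM and 14000 nM.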

Compound 4, half-maximal inhibitory concentration: 9700 nM
The estimate for compound 4 lay 1.5-fold (0.17 log units) below the measured number; low and high end bracket the measured number.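

In this assay, among the compounds shown here, replacing phenyl with 4-methylphenyl on the core of compound 3 gave a 1.3-fold higher number from compound 3 to compound 4 (0.12 log units; within the scatter), so the methyl group again made no step that stands out from the scatter. Set beside the earlier step, the two cores show no measurable difference in how they take this change: the same change on two cores in this assay, a 1.2-fold lower number (0.09 log units; within the scatter) from compound 1 to compound 2 and a 1.3-fold higher number (0.12 log units; within the scatter) from compound 3 to compound 4, 1.6-fold (0.21 log units) apart, within the scatter of two such steps. For the compounds shown here, this shows only that the change stays small on both of these cores; it does not show that a change with a large effect would carry across them in the same way.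

The compounds shown leave open what a larger or different group in the same place would do, such as an amine, a carboxylic acid or a longer chain. As far as these compounds go, whether such a group would give a clear step on either core, and whether that step would match on the other, also remains unknown.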